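From a hydroxyethyl amide to a piperidine amide

The source may hold more compounds than are shown below. What is called first, only, known or untested is meant among the compounds shown, and "the series" means these compounds.

The study concerns a shared core carrying a butoxy group and a phenyl group, tested in a functional assay on the whole organism (strain Wistar) for inhibition, with Rattus norvegicus as the target, read by paw edema, with stated times of 30 min and 3 h, at a dose of 100 mg/kg by the oral route; on this read-out higher numbers stand for more inhibition at the one dose given (going by the name of the read-out) and lower numbers for less inhibition. Compound 1 `CCCCOc1cc(C(=O)NCCC)nn1-c1ccccc1` bears a propyl amide and in this assay compound 1 gives 51.2%. Compound 2 `CCCCOc1cc(C(=O)NCCO)nn1-c1ccccc1` carries a 2-hydroxyethyl amide instead, and in this assay compound 2 gives 61.2%. Among the measured compounds shown here, the one step known so far, a number 10 percentage points higher from compound 1 to compound 2 (within the scatter), shows that hydroxy in place of methyl on a saturated chain carbon, two bonds along the chain from an amide-type nitrogen, produced no change beyond the scatter. Compound 2 stands highest of the two numbers, though its gap to compound 1 is within the scatter, so the two cannot be ordered.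

Compound 3 `CCCCOc1cc(C(=O)N2CCCCC2)nn1-c1ccccc1` differs from compound 2 by piperidin-1-yl in place of (2-hydroxyethyl)amino on a carbonyl carbon. For the measured compounds named here, no measured step touches the amide nitrogen itself, so the only guidance is that the one change tried so far on this amide side chain stayed within the scatter. The author therefore expects for compound 3 a step of a number 9.2 percentage points lower from compound 2 to compound 3 (within the scatter), not beyond the scatter. Compound 3 is estimated at 52%, with a range from 30% to 72%.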

Compound 3, a percentage reported as inhibition, in the whole organism at one dose (the size of the read-out at that dose, not a potency): 15.6%
Compound 3: middle estimate off by 36.4 percentage points, on the high side; measured number below the stated range.
By their numbers in this assay, from the lowest: compound 3; then compounds 1 and 2 (each within the scatter of the next).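

In this assay the substituent on this carbonyl carbon turns out to matter: piperidin-1-yl in place of (2-hydroxyethyl)amino gives a number 45.6 percentage points lower from compound 2 to compound 3 (beyond the scatter) and piperidin-1-yl in place of propylamino gives a number 35.6 percentage points lower from compound 1 to compound 3 (beyond the scatter) on the same shared core. The earlier swap of a chain end stayed within the scatter, so among the compounds shown, only the change from an open chain on an amide nitrogen that keeps the amide hydrogen to the piperidin-1-yl ring, which has no such hydrogen, separates the numbers beyond the scatter. Nothing available accounts for this fall in inhibition.

The compounds shown leave open whether the fall goes with the loss of the amide hydrogen or with the ring itself, since both changes arrive together in compound 3. A diethylamino group on the same carbonyl carbon would pull these two apart, and a morpholin-4-yl or pyrrolidin-1-yl group would show whether the fall holds for other rings in that place.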